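A few compounds are considered here, and "the series" means these few. Any claim that something is new, unique, unknown or untested is made for them only; others in the source may bear on it.

Working notes on a small set of flavonol ethers sharing one core.

Compound 1 `O=c1c(O)c(-c2ccccc2)oc2cc(OCc3cccc([N+](=O)[O-])c3)cc(O)c12` gives 76000 nM in an ADME assay on Huh-5-2 cells (Homo sapiens) for cytotoxicity, read by WST assay, with a stated time of 3 days; a lower number here means that less compound is tolerated, a higher number that more compound is tolerated. Compound 2 `Cc1cccc(COc2cc(O)c3c(=O)c(O)c(-c4ccccc4)oc3c2)c1` gives 35000 nM in this assay, and the step of a 2.2-fold lower number from compound 1 to compound 2 (0.34 log units; beyond the scatter) comes with the change (methyl in place of nitro on an aromatic carbon). Compound 3 `O=c1c(O)c(-c2ccccc2)oc2cc(OCc3ccc([N+](=O)[O-])cc3)cc(O)c12` gives 93000 nM in this assay; the step of a 1.2-fold higher number from compound 1 to compound 3 (0.09 log units; within the scatter) comes with the change (4-nitrophenyl in place of 3-nitrophenyl on a saturated chain carbon bound to an oxygen on an aromatic ring), and the step of a 2.7-fold higher number from compound 2 to compound 3 (0.42 log units; beyond the scatter) is also recorded.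

Compound 4 `Cc1ccc(COc2cc(O)c3c(=O)c(O)c(-c4ccccc4)oc3c2)cc1` has not been measured. Its difference from compound 3, (methyl in place of nitro on an aromatic carbon), is the same kind of change as methyl in place of nitro on an aromatic carbon, but the place differs: in compound 1 the exchanged group stands meta to a large group, in compound 3 para to a large group. The two cores differ by 4-nitrophenyl in place of 3-nitrophenyl on a saturated chain carbon bound to an oxygen on an aromatic ring.

For compound 4 the expected step is a 2.2-fold lower number from compound 3 to compound 4 (0.35 log units; beyond the scatter), which rests on the earlier step of a 2.2-fold lower number from compound 1 to compound 2 (0.34 log units; beyond the scatter). Compound 4 is thus estimated at 42000 nM, between 20000 nM and 90000 nM.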

Compound 4, half-maximal cytotoxic concentration: 88000 nM
Beside the measured number, compound 4's estimate is 2.1-fold (0.32 log units) below it; the measured number falls inside the stated range.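

Methyl in place of nitro on an aromatic carbon has now been read on two cores in this assay, and the two steps cannot be told apart: the same change on two cores in this assay, a 2.2-fold lower number (0.34 log units; beyond the scatter) from compound 1 to compound 2 and a 1.1-fold lower number (0.02 log units; within the scatter) from compound 3 to compound 4, 2.1-fold (0.31 log units) apart, within the scatter of two such steps. On the core of compound 3, with the group para to a large group, the change leaves the number within the scatter (a 1.1-fold lower number from compound 3 to compound 4 (0.02 log units; within the scatter)), whereas 4-methylphenyl in place of 3-methylphenyl gives a step beyond it (a 2.5-fold higher number from compound 2 to compound 4 (0.40 log units; beyond the scatter)) and 4-methylphenyl in place of 3-nitrophenyl one within it (a 1.2-fold higher number from compound 1 to compound 4 (0.06 log units; within the scatter)). One pair per core neither shows that the change carries from core to core nor shows that it fails to.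

From the compounds shown here alone, how an amine or a carboxylic acid in place of the nitro group would read in this assay stays open. So does the effect of a longer chain in place of the 4-methylbenzyl group.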